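Changing the aryl group of compound 2

The source may report more compounds than this note shows. Statements on the series, on what has been measured and on what is new or still open speak of the compounds shown alone.

Values in a functional assay on HL-60 cells (Homo sapiens) for antiproliferative activity, read by MTT assay, with a stated time of 72 h; a higher number here means a weaker inhibitor, a lower number a stronger inhibitor:
compound 1 `NC1=NC2(CCSCC2)N(OCCCOc2ccc(Br)cc2)C(N)=N1` gives 350 nM
compound 2 `NC1=NC2(CCOCC2)N(OCCCOc2cccc(Cl)c2Cl)C(N)=N1` gives 440 nM
compound 3 `NC1=NC2(CCSCC2)N(OCCCOc2cccc(Cl)c2Cl)C(N)=N1` gives 30 nM

Compound 2 at 440 nM lies within the scatter of compound 1 at 350 nM and has a much higher number than compound 3 at 30 nM on this scale. Compound 4 `NC1=NC2(CCOCC2)N(OCCCOc2cc(Cl)c(Cl)cc2Cl)C(N)=N1` keeps the core of compound 2 but carries 2,4,5-trichlorophenyl in place of 2,3-dichlorophenyl on an oxygen on a saturated carbon. Among the compounds with values here, only one measured step swaps this group: the large 12-fold lower number from compound 1 to compound 3 (1.07 log units; beyond the scatter). It shows that the group can matter in this assay, but it involves neither the incoming group nor the core of compound 2. With no measured direction for this change, the expected step is a 1.3-fold lower number from compound 2 to compound 4 (0.10 log units; within the scatter), with wide uncertainty. For compound 4 the estimated value is 350 nM (expected range 80 nM to 1500 nM).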

Compound 4, half-maximal inhibitory concentration: 2360 nM
For compound 4 the middle estimate is 6.7-fold (0.83 log units) below the measured one; the measured number lies above the stated range.
By their numbers in this assay, from the lowest: compound 3; then compounds 1 and 2 (each within the scatter of the next); then compound 4.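

In this assay, the aryl group on this oxygen also matters on the core of compound 2: 2,4,5-trichlorophenyl brings a 5.4-fold higher number from compound 2 to compound 4 (0.73 log units; beyond the scatter) and so a weaker inhibitor. The earlier compounds showed a swap of this group only on the core of compound 1, where it gave a stronger inhibitor, so among the compounds shown, changing this aryl group can move the number either way. Nothing measured here explains the rise.

The compounds shown leave open whether 2,4,5-trichlorophenyl would have the same effect on the core of compound 3. They also leave open how a pyridine ring in place of the aryl group would behave.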